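Pyrazoline amides: cytotoxicity notes for the next analogue

The compounds below may be only part of what the source reports. "The series", "measured", "known", "first", "only" and "open" are said of these compounds alone.

Measured so far:
compound 1 `CC1=NN(C(=O)CCc2ccccc2)C(c2cc(Br)cc(Br)c2O)C1` — 9170 nM
compound 2 `Cc1ccc(C(=O)N2N=C(c3cc4ccccc4oc3=O)CC2c2ccccc2)cc1` — 52300 nM

In a functional assay on HepG2 cells (Homo sapiens) for cytotoxicity, read by MTT assay, with a stated time of 48 h (on this read-out lower numbers stand for stronger inhibition and higher numbers for weaker inhibition), compound 1 gives 9170 nM and compound 2 gives 52300 nM. Compound 2 therefore stands as the higher of the two numbers, its nearest neighbour being compound 1, and the gap between them lies beyond the scatter. The two compounds share no single-point difference, so only their two values speak for them.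

Compound 3 `O=C(CN1CCC(O)CC1)N1N=C(c2cc3ccccc3oc2=O)CC1c1ccccc1` is not yet measured. It departs from compound 2 by the change ((4-hydroxypiperidin-1-yl)methyl in place of 4-methylphenyl on a carbonyl carbon).

Going by the values given here, no measured pair shows what this change does, so the step is expected to stay within the scatter: compound 3 is estimated to end up close to compound 2, with a 1.1-fold higher number from compound 2 to compound 3 (0.06 log units; within the scatter) as the expected step. The estimate for compound 3 in this assay is 60000 nM, with a range from 20000 nM to 200000 nM; a limit rather than a number is a real possibility here.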

Compound 3, half-maximal inhibitory concentration: "not active" (no number reported)
For compound 3 the study gives words and no number, so the estimate cannot be set against anything.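

Going by these compounds alone, compound 3 is reported in words with no number, and no step from compound 2 to compound 3 can be read. Nothing shown offers an explanation for this result.

On these data alone, how far replacing 4-methylphenyl with (4-hydroxypiperidin-1-yl)methyl shifts the cytotoxicity read-out remains open.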